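The source may hold more compounds than are shown below. What is called first, only, known or untested is meant among the compounds shown, and "the series" means these compounds.

Compound 1 `CCCCn1cnc2c(Nc3cccc(Cl)c3)nc(NCOCc3ccc(/C=C/C(=O)Nc4ccccc4N)cc3)nc21`: 30.4%
Compound 2 `Nc1ccccc1NC(=O)/C=C/c1ccc(COCNc2nc(Nc3cccc(Cl)c3)c3ncn(C4CCCC4)c3n2)cc1`: 14.8%

For the measured compounds named here, in a functional assay on HepG2 cells (Homo sapiens) for antiproliferative activity, read by CCK-8 assay, with a stated time of 72 h, tested at 8 uM (on this read-out higher numbers stand for a stronger effect at the one concentration tested and lower numbers for a weaker effect), compound 2 stands lowest of the two numbers, the one step in this set being a number 15.6 percentage points lower from compound 1 to compound 2 (beyond the scatter). Compound 3 `CC(C)n1cnc2c(Nc3cccc(Cl)c3)nc(NCOCc3ccc(/C=C/C(=O)Nc4ccccc4N)cc3)nc21` differs from compound 2 by isopropyl in place of cyclopentyl on an aromatic nitrogen. Going by the values given here, the only measured step that bears on this sits on the same aromatic nitrogen, where cyclopentyl in place of butyl gave a number 15.6 percentage points lower from compound 1 to compound 2 (beyond the scatter); returning to an open chain may recover part of that, though nothing tests isopropyl directly. A small rise, probably within the scatter, is expected: a number 7.2 percentage points higher from compound 2 to compound 3 (within the scatter). Compound 3 is therefore estimated at 22%, within 8% to 38%.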

Compound 3, a percentage reported as inhibition, at one concentration (the size of the read-out at that concentration, not a potency): 49.9%
Beside the measured number, compound 3's estimate is 27.9 percentage points below it, outside the stated range (above it).
By their numbers in this assay, from the lowest: compound 2; then compound 1; then compound 3.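

In this assay, the group on the aromatic nitrogen does more than separate butyl from cyclopentyl: isopropyl in place of cyclopentyl gives a number 35.1 percentage points higher from compound 2 to compound 3 (beyond the scatter), and isopropyl in place of butyl gives a number 19.5 percentage points higher from compound 1 to compound 3 (beyond the scatter). Isopropyl thus stands above both earlier groups, so the read-out does not simply follow ring against open chain, as the open-chain butyl stays lower. No evidence here accounts for this order. The compounds shown leave open whether ethyl, methyl or cyclopropyl on this nitrogen would extend the rise or lose it.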